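The compounds below may be only part of what the source reports. "The series", "measured", "known", "first", "only" and "open" are said of these compounds alone.

Compound 1 `CCC(C)c1cc(C2C(C#N)=C(N)OC3=C2C(=O)CCC3)cc2cc(-c3ccc(OC)cc3)c(=O)oc12` was tested in a functional assay on the whole organism (strain Swiss albino) with Mus musculus as the target, in the forced swim test, with a stated time of 5 min, at a dose of 0.5 mg/kg by the intraperitoneal route (on this read-out lower numbers stand for less inhibition and higher numbers for more inhibition at the one dose given (going by the name of the read-out)), and gave 35.1%. Compound 3 `COc1ccc(-c2cc3cc(C4C(C#N)=C(N)OC5=C4C(=O)CCC5)cc(C(C)(C)C)c3oc2=O)cc1` differs from it by a (tert-butyl in place of sec-butyl on an aromatic carbon); in this assay compound 3 gave 30.7%, so this change made a number 4.4 percentage points lower from compound 1 to compound 3 (within the scatter). Compound 2 `CCC(C)c1cc(C2C(C#N)=C(N)OC3=C2C(=O)CC(C)(C)C3)cc2cc(-c3ccc(OC)cc3)c(=O)oc12` carries a different core; the difference between the two cores is not broken down here. In this assay compound 2 gave 26.9%. Compound 4 `COc1ccc(-c2cc3cc(C4C(C#N)=C(N)OC5=C4C(=O)CC(C)(C)C5)cc(C(C)(C)C)c3oc2=O)cc1` is built from compound 2 by the same change, a (tert-butyl in place of sec-butyl on an aromatic carbon), and the surroundings of the place are described in the same words as before. The expected step is a number 2.9 percentage points lower from compound 2 to compound 4 (within the scatter), close to the earlier one, because a number 4.4 percentage points lower from compound 1 to compound 3 (within the scatter) stayed within the scatter. Compound 4 is therefore estimated at 24%, most likely between 13% and 36%.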

Compound 4, a percentage reported as inhibition, in the whole organism at one dose (the size of the read-out at that dose, not a potency): 27.2%
Compound 4: the middle estimate sits 3.2 percentage points below what was measured; the range from low to high includes it.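

In this assay, tert-butyl in place of sec-butyl gives a number 0.3 percentage points higher from compound 2 to compound 4 (within the scatter) and the two steps for this change can be set side by side: the same change on two cores in this assay, a number 4.4 percentage points lower (within the scatter) from compound 1 to compound 3 and a number 0.3 percentage points higher (within the scatter) from compound 2 to compound 4, 4.7 percentage points apart, within the scatter of two such steps. In this series, then, the change stays within the usual scatter on both cores, and the two steps cannot be told apart. This does not prove that the steps are identical, and two cores at one dose cannot show that the same would hold on a third core or at other doses.

On these data alone, what an amine, a carboxylic acid or a longer chain would do at this place remains open. The shown compounds compare only the two butyl groups there.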